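The compounds below may be only part of what the source reports. "The series", "measured", "known", "first", "only" and "open" are said of these compounds alone.

Measured so far in an assay on H4 cells for inhibition of Fatty-acid amide hydrolase 1 (Homo sapiens); on this read-out higher numbers stand for weaker inhibition and lower numbers for stronger inhibition:

Compound 1 `O=C(Nc1ccc(Oc2ccccc2)cc1)Oc1ccccc1F` gives 1300 nM
Compound 2 `CCCCCCCOc1ccc(NC(=O)Oc2ccccc2F)cc1` gives 28 nM
Compound 3 `CCCCOc1ccc(C(CC)NC(=O)Oc2ccccc2F)cc1` gives 7.7 nM

Compound 2 stands second highest of the three numbers; compound 3 sits lower, and compound 1 lies far above it, with the step of a 46-fold lower number from compound 1 to compound 2 (1.67 log units; beyond the scatter). Compound 4 `CCCCCCCCCCCCOc1ccc(NC(=O)Oc2ccccc2F)cc1` differs from compound 2 by pentyl in place of hydrogen on a saturated chain carbon, seven bonds along the chain from an oxygen on an aromatic ring. Among the measured compounds shown here, the only measured step that bears on this change is the one from compound 1 to compound 2, where a heptyl chain replaced a phenyl group and the number fell by a 46-fold lower number from compound 1 to compound 2 (1.67 log units; beyond the scatter). Lengthening the chain further has no precedent among the measured compounds, so the step of a 1.4-fold lower number from compound 2 to compound 4 (0.15 log units; within the scatter) is expected to be small, leaning toward a slightly lower number. Compound 4 is therefore estimated at 20 nM, within a range from 6 nM to 70 nM.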

Compound 4, half-maximal inhibitory concentration: 13 nM
Estimate against measurement, compound 4: 1.5-fold (0.19 log units) above, and the stated range covers the measured number.
By their numbers in this assay, from the lowest: compounds 3 and 4 (each within the scatter of the next); then compound 2; then compound 1.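

Adding pentyl on the saturated chain carbon, seven bonds along the chain from an oxygen on an aromatic ring, gives a 2.2-fold lower number from compound 2 to compound 4 (0.33 log units; beyond the scatter) in this assay. The earlier compounds shown here compared heptyl only with phenyl, whereas this pair shows that the chain can grow at this place without losing inhibition, and that inhibition becomes modestly stronger. No available evidence explains this step.

Going by these compounds, whether a still longer chain would strengthen inhibition further remains open. So does the effect of an amine or a carboxylic acid at this place.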